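Anilino replacement on the methoxystyrene series

This account rests on a few compounds, and the source may have more. Where it says the series, first, only, none or still open, it means among the compounds named here.

The series shares the core seen in compound 1 `C=C[C@@](C)(/C=C/c1ccc(OC)cc1)CCC=C(C)C`. In a functional assay on HepG2 cells (Homo sapiens) for cytotoxicity, with a stated time of 72 h (a lower number here means that less compound is needed, a higher number that more compound is needed for the effect), compound 1 reaches only the limit of the assay, giving > 52000 nM. Compound 2 `C=C[C@@](C)(/C=C/c1ccc(O)cc1)CCC=O` carries a free phenol and a shortened chain ending in an aldehyde; in this assay compound 2 likewise sits at the limit with > 52000 nM. Compound 3 `C=C[C@@](C)(/C=C/c1ccc(O)c(/C=C/C(=O)O)c1)CCC=C(C)C`, with a phenol and a carboxylic acid substituent on the ring, also stops at the limit, > 52000 nM. No number is therefore available for compound 1: its value is a limit, as are the other two, and the limit of > 52000 nM in this assay, at which 3 of the 3 values shown sit — all three measured members share the same outcome. Among the compounds with values here, no step between measured compounds can be sized.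

The unmeasured compound 4 `C=C[C@@](C)(/C=C/c1ccc(Nc2ccc(Cl)c(Cl)c2)cc1)CCC=C(C)C` differs from compound 1 by (3,4-dichlorophenyl)amino in place of methoxy on an aromatic carbon. With every measured member at the limit, the measured data give no anchor for sizing this change in this assay. The expected step is an at least 2.0-fold lower number from compound 1 to compound 4 (0.31 log units; beyond the scatter), in the direction of less compound being needed. For compound 4 the estimate in this assay is 25000 nM, with a range from 5000 nM to 60000 nM, and a fair chance that again only a limit is reported.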

Compound 4, half-maximal effective concentration: > 52000 nM
Compound 4 was reported as a limit; the forecaster's own chance of this, stated with the estimate: 50%; at least 2.0-fold (0.31 log units) between middle value and limit.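

In this assay compound 4 also gives only a limit, > 52000 nM. Compound 1 is a limit too, and the step from compound 1 to compound 4 cannot be read. What (3,4-dichlorophenyl)amino in place of methoxy does in this assay, and whether any member of the series gives a number there, stays open, with every compound shown at one limit: the limit of > 52000 nM in this assay, at which 4 of the 4 values shown sit.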